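Swapping cyclopentyl for an open branched group

The source may report more compounds than this note shows. Statements on the series, on what has been measured and on what is new or still open speak of the compounds shown alone.

Compound 1 `CC(C)c1c(NC(=O)Nc2cnc(-n3nccn3)c(Cl)c2)cnc2ccccc12` gives 2420 nM as its value
Compound 2 `O=C(Nc1cnc(-n2nccn2)c(Cl)c1)Nc1cnc2ccccc2c1C1CCCC1` gives 7020 nM as its value
Compound 3 `O=C(Nc1cnc(-n2nccn2)c(Cl)c1)Nc1cnc2cc(Cl)ccc2c1C1CC1` gives > 20000 nM as a limit, not a number
Compound 4 `COC(C)(C)c1c(NC(=O)Nc2cnc(-n3nccn3)c(Cl)c2)cnc2ccccc12` has not yet been measured

In a functional assay on OCI-Ly3 cells (Homo sapiens) for antiproliferative activity (on this read-out lower numbers stand for an effect already at smaller amounts and higher numbers for an effect only at larger amounts of compound), compound 2 has the higher of the two true numbers, and its nearest neighbour is compound 1 at 2420 nM on the lower side. Compound 3 reports only a limit, and it also differs from compound 2 in more than one place, so it offers no clean comparison.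

The next change is 1-methoxy-1-methylethyl in place of cyclopentyl on an aromatic carbon with 1-methoxy-1-methylethyl in place of cyclopentyl on an aromatic carbon. Going by the values given here, one measured step bears on this same carbon, a 2.9-fold higher number from compound 1 to compound 2 (0.46 log units; beyond the scatter) with cyclopentyl in place of isopropyl. Like isopropyl, the entering group has no ring, which points toward a modest return to lower numbers. However, none of the measured compounds carries the hydrogen-bond acceptor that this group brings, so the expectation stays loose.

The expected change is a 1.6-fold lower number from compound 2 to compound 4 (0.19 log units; within the scatter) in this assay by this estimate. Compound 4 is estimated at 4500 nM with an expected range from 1500 nM to 14000 nM in this estimate.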

Compound 4, half-maximal effective concentration: 4430 nM
For compound 4 the middle estimate is 1.0-fold (0.01 log units) above the measured one, and the stated range covers the measured number.
By their numbers in this assay, from the lowest: compounds 1, 4 and 2 (each within the scatter of the next, the first and the last beyond it). At a limit, above all of these: compound 3.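

In this assay, placing a methoxy on the saturated chain carbon of the isopropyl group of compound 1 gives a 1.8-fold higher number from compound 1 to compound 4 (0.26 log units; within the scatter) and so does not move the number beyond what repeat measurements would scatter. Replacing the cyclopentyl ring of compound 2 with the open 1-methoxy-1-methylethyl group gives a 1.6-fold lower number from compound 2 to compound 4 (0.20 log units; within the scatter) and is likewise not a clear change, although a ring leaves and an oxygen enters in the same step. Going by these compounds alone, compound 4 is the first compound here with a hydrogen-bond acceptor in the group on this aromatic carbon, and it lies within the scatter of both compound 1 and compound 2, even though those two differ from each other beyond the scatter.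

On these data alone, it remains open whether a hydroxy group or an amine such as dimethylamino, in place of the methoxy, would also leave the number within the scatter of compound 4. The data shown offer no explanation of why the oxygen of compound 4 leaves the number so little changed.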